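Enlarging the terminal amine ring in a cytotoxicity series

This account rests on a few compounds, and the source may have more. Where it says the series, first, only, none or still open, it means among the compounds named here.

Of the compounds shown here, two have so far been tested in a functional assay on K562 cells (Homo sapiens) for cytotoxicity, read by WST assay, with a stated time of 72 h; on this read-out lower numbers stand for stronger inhibition and higher numbers for weaker inhibition. Compound 1 `COc1cc2c(Nc3nc4ccc(C(=O)Nc5c(C)cccc5Cl)cc4s3)ncnc2cc1OCCCN1CCCCC1C` gives 6800 nM, while compound 2 `COc1cc2c(Nc3nc4ccc(C(=O)Nc5c(C)cccc5C)cc4s3)ncnc2cc1OCCCN1CCCC1` gives 15700 nM, the higher of the two numbers, with a gap that lies beyond the scatter. Compound 3 `COc1cc2c(Nc3nc4ccc(C(=O)Nc5c(C)cccc5C)cc4s3)ncnc2cc1OCCCN1CCCCC1C` introduces (2-methylpiperidin-1-yl in place of pyrrolidin-1-yl on a saturated chain carbon, three bonds along the chain from an oxygen on an aromatic ring). Among the compounds with values here, no measured pair differing in this one place exists, so only a modest step toward a lower number is expected, a 1.7-fold lower number from compound 2 to compound 3 (0.24 log units; within the scatter), and it may well stay within the scatter. Compound 3 is therefore estimated at 9000 nM in this assay, expected to fall between 4000 nM and 20000 nM.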

Compound 3, half-maximal inhibitory concentration: 12300 nM
Beside the measured number, compound 3's estimate is 1.4-fold (0.14 log units) below it; the measured number falls inside the stated range.
By their numbers in this assay, from the lowest: compounds 1, 3 and 2 (each within the scatter of the next, the first and the last beyond it).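

Exchanging pyrrolidin-1-yl for 2-methylpiperidin-1-yl gives a 1.3-fold lower number from compound 2 to compound 3 (0.11 log units; within the scatter) in this assay, so this assay does not tell these two amine rings apart. Methyl in place of chloro on an aromatic carbon gives a 1.8-fold higher number from compound 1 to compound 3 (0.26 log units; within the scatter) and likewise stays unresolved. No evidence bears on these results. As far as these compounds go, whether piperidin-1-yl without its methyl or morpholin-4-yl in that place would read differently remains open. So does the effect of fluoro or methoxy on that aromatic carbon.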